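This account rests on a few compounds, and the source may have more. Where it says the series, first, only, none or still open, it means among the compounds named here.

Three compounds share one core and differ only in the group on one aromatic carbon. Compound 1 `COc1ccc(-c2cn3ccnc3c(-c3ccc4ncn(C5CCCCC5)c4c3)n2)cc1` carries a methoxy group, and in a functional assay on MDA-MB-435 cells (Homo sapiens) for inhibition, read by sulforhodamine B assay, with a stated time of 48 h, tested at 10 uM (a lower number here means less inhibition, a higher number more inhibition at the concentration tested (going by the name of the read-out)), compound 1 gives -18.6%. Compound 2 `O=Cc1ccc(-c2cn3ccnc3c(-c3ccc4ncn(C5CCCCC5)c4c3)n2)cc1` carries a formyl group, and in this assay compound 2 gives 13%. Compound 3 `CC(=O)c1ccc(-c2cn3ccnc3c(-c3ccc4ncn(C5CCCCC5)c4c3)n2)cc1` carries an acetyl group, and in this assay compound 3 gives 6%. Among these three numbers compound 3 stands second highest: its nearest neighbour is compound 2, within the scatter, and its furthest is compound 1, beyond the scatter. The measured steps are a number 31.6 percentage points higher from compound 1 to compound 2 (beyond the scatter), a number 24.6 percentage points higher from compound 1 to compound 3 (beyond the scatter) and a number 7 percentage points lower from compound 2 to compound 3 (within the scatter).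

Compound 4 `Clc1ccc(-c2cn3ccnc3c(-c3ccc4ncn(C5CCCCC5)c4c3)n2)cc1` is not yet measured and differs from compound 3 in one place: chloro in place of acetyl on an aromatic carbon. Among the compounds with values here, no measured compound carries chloro, so this change has no direct precedent. Within the data shown here, the steps that bear on it are those concerning the acetyl, namely a number 24.6 percentage points higher from compound 1 to compound 3 (beyond the scatter) and a number 7 percentage points lower from compound 2 to compound 3 (within the scatter): compound 3 lies beyond the scatter above compound 1 and within the scatter of compound 2. Taking the acetyl away is expected to move the number in this assay downward, toward the level of compound 1, though the size is uncertain. Compound 4 is therefore estimated at -3%, within a range of -22% to 16%, an expected step of a number 9 percentage points lower from compound 3 to compound 4 (within the scatter).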

Compound 4, a percentage reported as inhibition, at one concentration (the size of the read-out at that concentration, not a potency): 36.7%
Beside the measured number, compound 4's estimate is 39.7 percentage points below it, outside the stated range (above it).
By their numbers in this assay, from the lowest: compound 1; then compounds 3 and 2 (each within the scatter of the next); then compound 4.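

In this assay a single chloro atom on this aromatic carbon gives the highest number of the series, with a number 30.7 percentage points higher from compound 3 to compound 4 (beyond the scatter) and a number 23.7 percentage points higher from compound 2 to compound 4 (beyond the scatter) and also a number 55.3 percentage points higher from compound 1 to compound 4 (beyond the scatter). The two groups without a carbonyl, methoxy and chloro, now stand at the two ends of the series, so the presence of a carbonyl does not order these numbers, and a higher number at this position does not require one. Nothing measured alongside these numbers accounts for the result.

Going by these compounds, whether bromo or fluoro would follow chloro, and whether an amine or a carboxylic acid on this carbon would fall nearer chloro or methoxy, remains open. On these data alone, all the numbers also come from one concentration, so the potency of compound 4 remains unknown.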